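Hydroxamic acid chain variants on the shared core

The source may report more compounds than this note shows. Statements on the series, on what has been measured and on what is new or still open speak of the compounds shown alone.

Values so far in a functional assay on HeLa cells (Homo sapiens) for inhibition, read by MTT assay, with a stated time of 48 h; on this read-out lower numbers stand for stronger inhibition and higher numbers for weaker inhibition
Compound 1 `O=C(CCCOc1no[n+]([O-])c1S(=O)(=O)c1ccccc1)NO` gives 4790 nM
Compound 2 `O=C(COCCOc1no[n+]([O-])c1S(=O)(=O)c1ccccc1)NO` gives 6690 nM

In this assay, among the compounds with values here, compound 2 lies within the scatter of compound 1, the only other number in hand. Within the data shown here, the one measured step (a 1.4-fold higher number from compound 1 to compound 2 (0.15 log units; within the scatter)) is (hydroxycarbamoyl)methoxy in place of (hydroxycarbamoyl)methyl on a saturated chain carbon, two bonds along the chain from an oxygen on an aromatic ring.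

Compound 3 `O=C(/C=C/COc1no[n+]([O-])c1S(=O)(=O)c1ccccc1)NO` is still unmeasured. Its difference from compound 2 (2-(hydroxycarbamoyl)ethenyl in place of ((hydroxycarbamoyl)methoxy)methyl on a saturated chain carbon bound to an oxygen on an aromatic ring) is 2-(hydroxycarbamoyl)ethenyl in place of ((hydroxycarbamoyl)methoxy)methyl on a saturated chain carbon bound to an oxygen on an aromatic ring. Among the measured compounds shown here, no measured compound carries the 2-(hydroxycarbamoyl)ethenyl group, so the data offer no direct precedent.

For the measured compounds named here, the only guide is the earlier chain change (a 1.4-fold higher number from compound 1 to compound 2 (0.15 log units; within the scatter)), which stayed within the scatter. No step beyond the scatter is therefore expected in this assay, and no direction can be argued with confidence. The estimated step (a 1.3-fold lower number from compound 2 to compound 3 (0.13 log units; within the scatter)) reflects that expectation. For compound 3 the estimated value is 5000 nM with an expected range from 2000 nM to 12000 nM on the strength of this single measured step.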

Compound 3, half-maximal inhibitory concentration: 8740 nM
Compound 3: the middle estimate sits 1.7-fold (0.24 log units) below what was measured; the range from low to high includes it.
By their numbers in this assay, from the lowest: compounds 1, 2 and 3 (each within the scatter of the next).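

In this assay, 2-(hydroxycarbamoyl)ethenyl on a saturated chain carbon bound to an oxygen on an aromatic ring gives a 1.3-fold higher number from compound 2 to compound 3 (0.12 log units; within the scatter) against the ((hydroxycarbamoyl)methoxy)methyl chain and a 1.8-fold higher number from compound 1 to compound 3 (0.26 log units; within the scatter) against the 2-(hydroxycarbamoyl)ethyl chain. The earlier pair showed only that a chain oxygen could be present without a step beyond the scatter; the new steps extend this to a chain with a double bond, so all three chains at this position now lie within the scatter of one another. No measurement on these compounds bears on why the read-out stays so flat across the three chains.

Still open, on these data alone, is whether any change at this position can produce a step beyond the scatter, for instance a carboxylic acid in place of the hydroxycarbamoyl end, an amine in the chain, or a longer chain ending in the same hydroxycarbamoyl group. The three compounds also share one core and one read-out, so they leave open whether the same flat picture would hold on a different core or in another assay.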